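The compounds below may be only part of what the source reports. "The series", "measured", "known", "first", "only" and "open" are said of these compounds alone.

Measured so far in an ADME assay on L929 cells (Mus musculus) for antiproliferative activity, read by CCK-8 assay, with a stated time of 48 h; a higher number here means a weaker inhibitor, a lower number a stronger inhibitor:
compound 1, `CCCCSc1n[nH]c(-n2[se]c3ccccc3c2=O)n1`: 30400 nM
compound 2, `CC(C)CSc1n[nH]c(-n2[se]c3ccccc3c2=O)n1`: 33400 nM
compound 3, `O=c1c2ccccc2[se]n1-c1nc(SCc2ccc(Cl)cc2)n[nH]1`: 39500 nM

Compound 1 gives the smallest number of the three, but it is not separated from the others: a 1.1-fold higher number from compound 1 to compound 2 (0.04 log units; within the scatter) and a 1.3-fold higher number from compound 1 to compound 3 (0.11 log units; within the scatter) both lie within the scatter, as does a 1.2-fold higher number from compound 2 to compound 3 (0.07 log units; within the scatter). Across propyl, isopropyl and 4-chlorophenyl on the saturated chain carbon bound to the sulfur, this assay is flat.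

Compound 4, `CC(C)Sc1n[nH]c(-n2[se]c3ccccc3c2=O)n1`, differs from compound 1 as follows: isopropyl in place of butyl on a sulfur. Cut one bond further out, this reads butylsulfanyl to isopropylsulfanyl. For the measured compounds named here, the three measured steps all vary the group at the sulfur side chain and none moved this assay beyond the scatter; no measured step removes a carbon directly from the chain, so that part of the change is untested. On the evidence in hand, the expected step of a 1.1-fold higher number from compound 1 to compound 4 (0.02 log units; within the scatter) is none beyond the scatter. Compound 4 is therefore estimated at 32000 nM in this assay, with a range of 16000 nM to 64000 nM.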

Compound 4, half-maximal inhibitory concentration: 37100 nM
Compound 4: middle estimate off by 1.2-fold (0.06 log units), on the low side, within the range that was stated.
By their numbers in this assay, from the lowest: compounds 1, 2, 4 and 3 (each within the scatter of the next).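

In this assay, the shorter isopropyl on the sulfur stays within the scatter of each of the other three groups (a 1.2-fold higher number from compound 1 to compound 4 (0.09 log units; within the scatter); a 1.1-fold higher number from compound 2 to compound 4 (0.05 log units; within the scatter); a 1.1-fold lower number from compound 3 to compound 4 (0.03 log units; within the scatter)). For the compounds shown here, the loss of a carbon from butyl, which the earlier steps left untested, therefore brings no separable change, and the flat reading now extends to isopropyl alongside butyl, isobutyl and 4-chlorobenzyl in compounds 1 to 4. No supporting data bear on the reason for this flat result.

On these data alone, it remains open whether the flat reading would hold with an amine, a carboxylic acid or a much longer chain on the sulfur. The effect of replacing the sulfur with an oxygen or an amine nitrogen, or of changing the shared core, is also unresolved.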